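The source may report more compounds than this note shows. Statements on the series, on what has been measured and on what is new or still open speak of the compounds shown alone.

Of the compounds shown here, three that share one core have been measured in a functional assay, with a stated time of 15 min, tested at 20 uM; on this read-out higher numbers stand for a stronger effect at the one concentration tested and lower numbers for a weaker effect. Compound 1 `COc1cc(OC)cc(-n2c(-c3ccccc3)nc(C)c2C)c1` gives 32.4%. Compound 2 `COc1ccc(-n2c(-c3ccc(F)cc3)nc(C)c2C)cc1` gives 39%, and compound 3 `COc1ccc(-n2c(-c3ccccc3)nc(C)c2C)cc1` gives 28.1%. Among these three numbers compound 1 stands second highest, but its difference to compound 3 and its difference to compound 2 both stay within the scatter of repeated measurements, so no real order between them can be read from the data. Going by the values given here, the one step that goes beyond the scatter runs a number 10.9 percentage points lower from compound 2 to compound 3 (beyond the scatter), the change of hydrogen in place of fluoro on an aromatic carbon.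

Compound 4 `COc1cc(OC)cc(-n2c(-c3ccc(F)cc3)nc(C)c2C)c1` has not yet been measured. It differs from compound 1 by fluoro in place of hydrogen on an aromatic carbon. This is the same change as the measured step, taken in the opposite direction, so that step is the one that bears on it. Because a number 10.9 percentage points lower from compound 2 to compound 3 (beyond the scatter) removed a fluoro and lowered the read-out modestly, putting the fluoro in is expected to raise it by about the same amount. The step expected in this assay is therefore a number 9.6 percentage points higher from compound 1 to compound 4 (within the scatter). On that basis compound 4 is estimated at 42%, with a plausible range from 30% to 54%.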

Compound 4, a percentage reported as activity, at one concentration (the size of the read-out at that concentration, not a potency): 24.8%
For compound 4 the middle estimate is 17.2 percentage points above the measured one; the whole stated range lies above it.
By their numbers in this assay, from the lowest: compounds 4, 3, 1 and 2 (each within the scatter of the next, the first and the last beyond it).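

In this assay, the change from phenyl to 4-fluorophenyl on the core of compound 1 gives a number 7.6 percentage points lower from compound 1 to compound 4 (within the scatter), so on this core the fluoro brings no gain that can be told apart from the scatter. Before this result, the only view of the change came from the core of compound 2 and compound 3, where the fluoro-bearing compound gave the higher number, and that single step could have been read as a general benefit of fluoro at this place, on an aromatic carbon para to a large group. The new step shows that this reading does not carry over, and that the outcome of the same swap differs with the core that carries it: the same change on two cores in this assay, a number 10.9 percentage points lower (beyond the scatter) from compound 2 to compound 3 and a number 7.6 percentage points higher (within the scatter) from compound 4 to compound 1, 18.5 percentage points apart, beyond the scatter of two such steps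

The compounds shown hold only hydrogen or fluoro at this place, so how a chlorine atom, a trifluoromethyl group or an amine would behave there on either core stays open. Each number also comes from one concentration, so it speaks only of a stronger or weaker effect at that concentration.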